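The source may report more compounds than this note shows. Statements on the series, on what has been measured and on what is new or still open speak of the compounds shown alone.

Of the compounds shown here, three sharing one core have been measured in a functional assay on LNCaP cells (Homo sapiens) for antiproliferative activity, read by CCK-8 assay, with a stated time of 6 days; on this read-out higher numbers stand for weaker inhibition and lower numbers for stronger inhibition. Compound 1 `CC(O)c1cccc(C(=O)N[C@@H](C)Cn2ccc(-c3ccc(C#N)c(Cl)c3)n2)c1` gives 2280 nM, compound 2 `CC(=O)c1ccc(C(=O)N[C@@H](C)Cn2ccc(-c3ccc(C#N)c(Cl)c3)n2)cc1` gives 3600 nM, and compound 3 `C[C@@H](Cn1ccc(-c2ccc(C#N)c(Cl)c2)n1)NC(=O)c1ccccc1F` gives 1810 nM. Compound 3 carries the lowest number of the three, but its steps to the others stay within the scatter: a 1.3-fold lower number from compound 1 to compound 3 (0.10 log units; within the scatter) and a 2.0-fold lower number from compound 2 to compound 3 (0.30 log units; within the scatter). The step between the other two is likewise small, a 1.6-fold higher number from compound 1 to compound 2 (0.20 log units; within the scatter). Compound 4 `COC(=O)/C=C/C(=O)N[C@@H](C)Cn1ccc(-c2ccc(C#N)c(Cl)c2)n1` differs from compound 3 in that (2-(methoxycarbonyl)ethenyl in place of 2-fluorophenyl on a carbonyl carbon). Among the measured compounds shown here, every measured step exchanged one aromatic ring for another on the carbonyl carbon, and none moved the number beyond the scatter; no measured step exchanges the ring for a chain of this kind, so the change leading to compound 4 lacks a direct precedent. On that basis the expected step in this assay is a 1.5-fold higher number from compound 3 to compound 4 (0.19 log units; within the scatter), leaning toward a higher number but carrying wide uncertainty. Compound 4 is therefore estimated at 2800 nM, within a range from 800 nM to 10000 nM.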

Compound 4, half-maximal inhibitory concentration: 2460 nM
Compound 4: the middle estimate sits 1.1-fold (0.06 log units) above what was measured; measured number inside the range.
By their numbers in this assay, from the lowest: compounds 3, 1, 4 and 2 (each within the scatter of the next).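

In this assay, a chain without a ring, 2-(methoxycarbonyl)ethenyl, takes the place of the aromatic ring on the carbonyl carbon, and the number stays within the scatter of all three earlier compounds (a 1.4-fold higher number from compound 3 to compound 4 (0.13 log units; within the scatter); a 1.1-fold higher number from compound 1 to compound 4 (0.03 log units; within the scatter); a 1.5-fold lower number from compound 2 to compound 4 (0.17 log units; within the scatter)). The earlier compounds shown here had only exchanged one aromatic ring for another at this place, whereas compound 4 shows that, in this series, the number holds without any ring there. Nothing available here accounts for this result.

As far as these compounds go, it remains open whether a carboxylic acid in place of the methyl ester of that chain, or a saturated chain without its double bond, would also stay within the scatter. An amine-bearing chain on the same carbonyl carbon is equally untested by the compounds shown, so it is unknown whether any group at this place moves the number beyond the scatter.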